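This account rests on a few compounds, and the source may have more. Where it says the series, first, only, none or still open, it means among the compounds named here.

Of the compounds shown here, two that share one core have been measured in an assay on isolated protein for binding affinity to melanin-concentrating hormone receptor 1 (Homo sapiens); on this read-out lower numbers stand for stronger inhibition and higher numbers for weaker inhibition. Compound 1 `COc1cccc(C(=O)NC2CCN(Cc3ccc4ccccc4c3)CC2)c1` gives 29 nM, and compound 2 `COc1cc(C(=O)NC2CCN(Cc3ccc4ccccc4c3)CC2)cc(OC)c1OC` gives 286 nM. Of these two numbers compound 1 has the lower one, and the number for compound 2 lies higher by a margin well beyond the usual scatter, so compound 1 stands as the stronger binder of the pair. Compound 3 `O=C(NC1CCN(Cc2ccc3ccccc3c2)CC1)c1ccc(F)c(F)c1` has not yet been measured. It differs from compound 1 in one place: 3,4-difluorophenyl in place of 3-methoxyphenyl on a carbonyl carbon. Within the data shown here, no measured pair shows this particular exchange, so any expectation rests on the single known value of compound 1 alone. The step is expected to be modest, a 1.6-fold higher number from compound 1 to compound 3 (0.19 log units; within the scatter), possibly staying within the scatter and leaning, if anywhere, toward a weaker number. Compound 3 is therefore estimated at 45 nM in this assay, with a range from 12 nM to 160 nM.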

Compound 3, inhibition constant: 18 nM
For compound 3 the middle estimate is 2.5-fold (0.40 log units) above the measured one, within the range that was stated.
By their numbers in this assay, from the lowest: compounds 3 and 1 (each within the scatter of the next); then compound 2.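

In this assay the exchange of 3-methoxyphenyl for 3,4-difluorophenyl on a carbonyl carbon gives a small step (a 1.6-fold lower number from compound 1 to compound 3 (0.21 log units; within the scatter)), so the two compounds cannot be told apart on this read-out. The position therefore accepts a group with no hydrogen-bond acceptor in place of one with a single acceptor, and the oxygen of the 3-methoxyphenyl group is not needed for a number of this size. Nothing measured here explains this outcome.

The compounds shown do not tell whether a single fluorine, a chlorine or a nitrile on the phenyl ring would hold a number in this range. Nor do they tell whether a cyclohexyl group on the same carbonyl carbon, with no aromatic ring at all, would do so.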